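Bromo-to-carbamoyl swap on the shared core

This account rests on a few compounds, and the source may have more. Where it says the series, first, only, none or still open, it means among the compounds named here.

Measured so far:
compound 1 `O=C(Nc1cc(C(F)(F)F)cc(C(F)(F)F)c1)c1ccccc1O`: > 100000 nM
compound 2 `O=C(Nc1cc(C(F)(F)F)cc(C(F)(F)F)c1)c1cc(Br)ccc1O`: 13000 nM

In an assay for inhibition of transmembrane protease serine 4 (Homo sapiens), read by fluorescence (on this read-out higher numbers stand for weaker inhibition and lower numbers for stronger inhibition), compound 1 gives only a limit, > 100000 nM. For the measured compounds named here, compound 2 gives 13000 nM, the only number in this assay. Going by the values given here, the other value shown for this assay is the one that compound 1 reaches as a limit. Among the compounds with values here, the one measured step, an at least 7.6-fold lower number from compound 1 to compound 2 (0.88 log units; beyond the scatter), concerns a different change and at one end sits at the limit (the limit of > 100000 nM in this assay, at which 1 of the 2 values shown sits). Compound 3 `NC(=O)c1ccc(O)c(C(=O)Nc2cc(C(F)(F)F)cc(C(F)(F)F)c2)c1` carries carbamoyl in place of bromo on an aromatic carbon. Within the data shown here, no measured step bears on this change, so no direction is known. A number near that of compound 2 is expected for compound 3, 20000 nM, between 3000 nM and 100000 nM. The expected step is a 1.5-fold higher number from compound 2 to compound 3 (0.19 log units; within the scatter), within the scatter.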

Compound 3, half-maximal inhibitory concentration: > 100000 nM
Compound 3: a limit, no number (the forecaster's own chance of this, stated with the estimate: 30%); middle value at least 5.0-fold (0.69 log units) away from the limit.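

Carbamoyl in place of bromo on this aromatic carbon, para to a hydroxy group, gives an at least 7.6-fold higher number from compound 2 to compound 3 (0.88 log units; beyond the scatter), so the gain in compound 2 does not extend to every group at this position. Compound 3 gives only a limit, > 100000 nM, not a number, and that limit now covers most of the set: the limit of > 100000 nM in this assay, at which 2 of the 3 values shown sit. The step between compound 1 and compound 3 cannot be read; both values are limits.

Open, from the compounds shown here alone, is whether chloro, a methyl group, a nitrile or a carboxylic acid at this position would give a number, and how any of them would compare with bromo.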